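From 1-methylheptyl to decyl on the shared core

The source may report more compounds than this note shows. Statements on the series, on what has been measured and on what is new or still open speak of the compounds shown alone.

Of the compounds shown here, two with the same core have been measured so far in an ADME assay on Vero cells (Chlorocebus sabaeus) for cytotoxicity, read by reporter gene assay, with a stated time of 4 days; a lower number here means a stronger inhibitor, a higher number a weaker inhibitor. Compound 1 `CCCCCC(=O)OCC(C)(C)CC1=C(O)C(=O)c2ccccc2C1=O` gives 169000 nM, while compound 2 `CCCCCCC(C)C(=O)OCC(C)(C)CC1=C(O)C(=O)c2ccccc2C1=O` gives 450 nM, the lower of the two numbers.

The next compound, compound 3 `CCCCCCCCCCC(=O)OCC(C)(C)CC1=C(O)C(=O)c2ccccc2C1=O`, keeps that core and changes a single group: decyl in place of 1-methylheptyl on a carbonyl carbon. In words, this is decyl in place of 1-methylheptyl on a carbonyl carbon.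

Among the measured compounds shown here, only one measured step bears on this change. It is a 380-fold lower number from compound 1 to compound 2 (2.57 log units; beyond the scatter), seen when 1-methylheptyl took the place of pentyl on that same carbonyl carbon. For the measured compounds named here, no measured compound carries decyl, and one step cannot establish a pattern. Even so, that large step suggests the number may stay low with a longer chain, so a much smaller change is expected this time, probably upward. The estimated change is a 2.2-fold higher number from compound 2 to compound 3 (0.35 log units; beyond the scatter). In this assay, compound 3 is estimated at 1000 nM, with an expected range from 150 nM to 8000 nM.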

Compound 3, half-maximal inhibitory concentration: > 233000 nM
Compound 3: no number, only a limit; the forecaster's own chance of this, stated with the estimate: 5%; middle value at least 230-fold (2.36 log units) away from the limit.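

In this assay, the reading for compound 3 is a limit and not a number: the limit of > 233000 nM in this assay, at which 1 of the 3 values shown sits. Replacing 1-methylheptyl with decyl on this carbonyl carbon gives an at least 510-fold higher number from compound 2 to compound 3 (2.71 log units; beyond the scatter), so a longer chain at this position does not by itself keep the number low, and the low number of compound 2 stands alone among the three compounds. The other new step, an at least 1.3-fold higher number from compound 1 to compound 3 (0.13 log units; that floor lies within the scatter), does not separate the pentyl chain from the decyl chain, so the two compounds without the 1-methyl branch cannot be placed in order, although neither comes close to compound 2.

The compounds shown change the branch and the chain length together, so they leave open whether the low number of compound 2 goes with the methyl branch, with a chain of that particular size, or with both; a straight octyl chain and a 1-methylnonyl chain at the same place would help to separate these. Also open, from the compounds shown here alone, is how the number would respond to a chain ending in an amine or a carboxylic acid.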